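Propargyl for methyl on the arylamine nitrogen of compound 2

A few compounds are considered here, and "the series" means these few. Any claim that something is new, unique, unknown or untested is made for them only; others in the source may bear on it.

Measured compounds in an assay on L1210 cells for inhibition of Thymidylate synthase (Mus musculus); a lower number here means a stronger inhibitor, a higher number a weaker inhibitor:
compound 1 `C#CCN(Cc1ccc2nc(C)nc(O)c2c1)c1ccc(C(=O)N[C@@H](CCC(=O)O)C(=O)N2CCCC2C(=O)O)cc1`: 35 nM
compound 2 `Cc1nc(O)c2cc(CN(C)c3ccc(C(=O)N[C@@H](CCC(=O)O)C(=O)N(C)[C@@H](CCC(=O)O)C(=O)O)c(F)c3)ccc2n1`: 23 nM
compound 3 `Cc1nc(O)c2cc(CN(C)c3ccc(C(=O)N[C@@H](CCC(=O)O)C(=O)N(C)[C@@H](CCC(=O)O)C(=O)O)c(F)c3)c(C)cc2n1`: 3 nM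

Among the compounds with values here, compound 2 stands second highest of the three numbers in this assay; compound 1 sits nearest, within the scatter, and compound 3 lies furthest, with the step of a 7.7-fold lower number from compound 2 to compound 3 (0.88 log units; beyond the scatter) being the only measured step in the set and concerning methyl in place of hydrogen on an aromatic carbon.

Compound 4 `C#CCN(Cc1ccc2nc(C)nc(O)c2c1)c1ccc(C(=O)N[C@@H](CCC(=O)O)C(=O)N(C)[C@@H](CCC(=O)O)C(=O)O)c(F)c1` is not yet measured. It differs from compound 2 by ethynyl in place of hydrogen on a saturated chain carbon bound to a nitrogen on an aromatic ring. Within the data shown here, no measured step bears on this change. Among the measured compounds shown here, compound 1 carries the same propargyl group but differs from compound 2 in several further places, so the pair shows only two values, which lie within the scatter of each other. On that thin basis no step beyond the scatter is expected in this assay, with a slight lean toward a lower number. Compound 4 is estimated at 15 nM, range 5 nM to 50 nM, an expected step of a 1.5-fold lower number from compound 2 to compound 4 (0.19 log units; within the scatter).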

Compound 4, inhibition constant: 4 nM
Compound 4: the middle estimate sits 3.8-fold (0.57 log units) above what was measured; the measured number lies below the stated range.
By their numbers in this assay, from the lowest: compounds 3 and 4 (each within the scatter of the next); then compounds 2 and 1 (each within the scatter of the next).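

Methyl to propargyl at this place, on a saturated chain carbon bound to a nitrogen on an aromatic ring, gives in this assay the first single-change reading for this position: a 5.8-fold lower number from compound 2 to compound 4 (0.76 log units; beyond the scatter). The position therefore responds to the added ethynyl, which the closeness of compound 1 and compound 2 could not show, as those two differ in several further places. No measurement on hand accounts for this step.

Open, as far as these compounds go, is how a saturated ethyl or propyl chain, or a hydroxyethyl chain, would compare with propargyl at this place. Also open, from the compounds shown here alone, is whether propargyl combines with the methyl on an aromatic carbon, the change behind a 7.7-fold lower number from compound 2 to compound 3 (0.88 log units; beyond the scatter), in a single compound.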